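A few compounds are considered here, and "the series" means these few. Any claim that something is new, unique, unknown or untested is made for them only; others in the source may bear on it.

Compound 1 `COc1ccc2c(c1)c(C1CC(c3ccccc3)=NN1C(=O)c1ccc(OC)nc1)cn2C` gives 990 nM in a functional assay on MCF7 cells (Homo sapiens) for inhibition, read by MTT assay, with a stated time of 48 h; on this read-out higher numbers stand for weaker inhibition of growth and lower numbers for stronger inhibition of growth.
Compound 2 `COc1ccc2c(c1)c(C1CC(c3ccc(Cl)cc3)=NN1C(=O)c1ccc(OC)nc1)cn2C` gives 3710 nM in this assay.
Compound 3 `COc1ccc2c(c1)c(C1CC(c3ccc(Br)cc3)=NN1C(=O)c1ccc(OC)nc1)cn2C` gives 6960 nM in this assay.

Compound 3 has the highest of the three numbers. Its step from compound 2 is a 1.9-fold higher number from compound 2 to compound 3 (0.27 log units; within the scatter), so these two compounds cannot be ranked against each other, while the step from compound 1 is a 7.0-fold higher number from compound 1 to compound 3 (0.85 log units; beyond the scatter). Compound 4 `COc1ccc(C2=NN(C(=O)c3ccc(OC)nc3)C(c3cn(C)c4ccc(OC)cc34)C2)cc1` differs from compound 3 in one place: methoxy in place of bromo on an aromatic carbon. Going by the values given here, no measured step puts a methoxy on this aromatic carbon, so the evidence is indirect. The steps of a 3.7-fold higher number from compound 1 to compound 2 (0.57 log units; beyond the scatter) and a 7.0-fold higher number from compound 1 to compound 3 (0.85 log units; beyond the scatter) show that chloro or bromo on this carbon gave higher numbers than hydrogen, but they say nothing about what a methoxy does. The expected step is therefore uncertain in direction and is taken as a 2.8-fold lower number from compound 3 to compound 4 (0.44 log units; beyond the scatter), leaning toward a number between that of compound 1 and compound 3. Compound 4 is estimated at 2500 nM, with a range from 700 nM to 9000 nM.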

Compound 4, concentration for 50% growth inhibition: 560 nM
Compound 4: middle estimate off by 4.5-fold (0.65 log units), on the high side, outside the stated range (below it).
By their numbers in this assay, from the lowest: compounds 4 and 1 (each within the scatter of the next); then compounds 2 and 3 (each within the scatter of the next).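

The earlier compounds shown here showed only that chloro and bromo on this aromatic carbon gave higher numbers than hydrogen, and methoxy now shows that a group here need not do so: in this assay, a 1.8-fold lower number from compound 1 to compound 4 (0.25 log units; within the scatter) leaves the two compounds unranked. Among the groups shown, the outcome depends on which group stands on this carbon, as methoxy separates clearly from both halogens, with a 12-fold lower number from compound 3 to compound 4 (1.09 log units; beyond the scatter) against bromo and a 6.6-fold lower number from compound 2 to compound 4 (0.82 log units; beyond the scatter) against chloro. Nothing measured here accounts for this difference between methoxy and the halogens.

The compounds shown leave open how an amine, a hydroxyl or a longer chain such as ethoxy would read on this aromatic carbon. They also leave open whether methoxy on another carbon of that ring would give a similar number.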